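The compounds below may be only part of what the source reports. "The series", "measured", "known", "first", "only" and "open" are said of these compounds alone.

Measured compounds:
compound 1, `C=CCN1CCC(c2noc(COc3ccc(/C=C/C(=O)NO)cc3)n2)CC1`: 66%
compound 2, `Cc1cccc(CN2CCC(c3noc(COc4ccc(/C=C/C(=O)NO)cc4)n3)CC2)c1`: 73%
compound 3, `Cc1ccc(CN2CCC(c3noc(COc4ccc(/C=C/C(=O)NO)cc4)n3)CC2)cc1`: 76%

All three numbers come from an assay on isolated protein for inhibition of protein deacetylase HDAC6 (Homo sapiens), read by fluorescence, with a stated time of 1 h, tested at 100 nM; on this read-out higher numbers stand for more inhibition at the one concentration tested (going by the name of the read-out) and lower numbers for less inhibition. Compound 1 stands lowest of the three; the steps from it are a number 7 percentage points higher from compound 1 to compound 2 (within the scatter) and a number 10 percentage points higher from compound 1 to compound 3 (within the scatter), so the three values sit together within the scatter.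

Compound 4, `O=C(/C=C/c1ccc(OCc2nc(C3CCN(Cc4ccc(F)cc4)CC3)no2)cc1)NO`, is still to be measured in this assay. Its change from compound 1 is 4-fluorophenyl in place of vinyl on a saturated chain carbon bound to an amine nitrogen in a ring. The two measured steps from compound 1 bear on it directly: each replaces the vinyl with a methylphenyl on the same saturated chain carbon, and neither moves the number beyond the scatter. A six-membered aromatic ring enters here as well, so no step beyond the scatter is expected. For compound 4 the estimate is 72% in this assay, ranging 60% to 84%, which is expected to mean a number 6 percentage points higher from compound 1 to compound 4 (within the scatter).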

Compound 4, a percentage reported as inhibition, at one concentration (the size of the read-out at that concentration, not a potency): 75%
The estimate for compound 4 lay 3 percentage points below the measured number; low and high end bracket the measured number.
By their numbers in this assay, from the lowest: compounds 1, 2, 4 and 3 (each within the scatter of the next).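

At the saturated chain carbon bound to an amine nitrogen in a ring, 4-fluorophenyl in place of vinyl (a number 9 percentage points higher from compound 1 to compound 4 (within the scatter)) shows that an aromatic ring carrying fluoro instead of methyl also stays within the scatter. Fluoro in place of methyl on an aromatic carbon (a number 1 percentage points lower from compound 3 to compound 4 (within the scatter)) and 4-fluorophenyl in place of 3-methylphenyl (a number 2 percentage points higher from compound 2 to compound 4 (within the scatter)) leave these compounds unseparated. Nothing available explains these small steps.

The compounds shown leave open whether a carboxylic acid or an amine on the aromatic ring, or a longer chain before it, would give a step beyond the scatter.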